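Series notes: ethyl to cyclohexyl on the ring carbon

The source may hold more compounds than are shown below. What is called first, only, known or untested is meant among the compounds shown, and "the series" means these compounds.

Measured in a functional assay on SW1573 cells (Homo sapiens) for antiproliferative activity; on this read-out higher numbers stand for weaker inhibition of growth and lower numbers for stronger inhibition of growth:
compound 1 `CC(C)CC1OCCC(Cl)=C1[Si](C)(C)C` gives 10000 nM
compound 2 `C[C@H]1CC(Cl)=C([Si](C)(C)C)[C@@H](C2CCCCC2)O1` gives 16000 nM
compound 3 `CC[C@H]1CC(Cl)=C([Si](C)(C)C)[C@@H](C2CCCCC2)O1` gives 22000 nM

Compound 3 shows the highest of the three numbers in this assay; compound 2 sits within the scatter of it, while compound 1 lies beyond the scatter on the lower side. Compound 4 `C[Si](C)(C)C1=C(Cl)C[C@H](C2CCCCC2)O[C@@H]1C1CCCCC1` differs from compound 3 by cyclohexyl in place of ethyl on a saturated ring carbon. Among the measured compounds shown here, the only single-place step among the measured compounds is a 1.4-fold higher number from compound 2 to compound 3 (0.14 log units; within the scatter). Compound 1 and compound 2 differ in more than one place, so their values are read only as they stand. One step within the scatter gives no basis for a large move, and the step of a 1.1-fold lower number from compound 3 to compound 4 (0.04 log units; within the scatter) is expected to stay within the scatter. Compound 4 is estimated at 20000 nM, with a range of 8000 nM to 50000 nM in this assay.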

Compound 4, concentration for 50% growth inhibition: 23000 nM
Compound 4: the middle estimate sits 1.2-fold (0.06 log units) below what was measured; the measured number falls inside the stated range.
By their numbers in this assay, from the lowest: compounds 1, 2, 3 and 4 (each within the scatter of the next, the first and the last beyond it).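

On the saturated ring carbon next to the ring oxygen, this assay does not separate the groups shown: cyclohexyl in place of ethyl gives (a 1.0-fold higher number from compound 3 to compound 4 (0.02 log units; within the scatter)) and cyclohexyl in place of methyl gives (a 1.4-fold higher number from compound 2 to compound 4 (0.16 log units; within the scatter)). This extends the earlier reading from a small chain change to a much larger carbon ring, still without a step beyond the scatter. No evidence on the cause of this flat result is available.

As far as these compounds go, whether a group carrying an amine or a carboxylic acid on this carbon would move the number remains open.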